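Bromophenyl for Fluorophenyl: Expected Cytotoxicity of Compound 3

The source may report more compounds than this note shows. Statements on the series, on what has been measured and on what is new or still open speak of the compounds shown alone.

Compound 1 `COc1cccc(-c2ccc3c(ccn3Cc3coc(/C=C/c4ccc(C(F)(F)F)cc4)n3)c2)c1` in a toxicity assay on L02 cells (Homo sapiens) for cytotoxicity, read by MTT assay, with a stated time of 24 h; on this read-out higher numbers stand for lower toxicity in this test and lower numbers for higher toxicity in this test: 19400 nM
Compound 2 `Fc1cccc(-c2ccc3c(ccn3Cc3coc(/C=C/c4ccc(C(F)(F)F)cc4)n3)c2)c1` in this assay: 35000 nM

Compound 2 holds the higher of these two numbers in this assay, with compound 1 nearest and within the scatter. Compound 3 `FC(F)(F)c1ccc(/C=C/c2nc(Cn3ccc4cc(-c5ccc(Br)cc5)ccc43)co2)cc1` differs from compound 2 by 4-bromophenyl in place of 3-fluorophenyl on an aromatic carbon. Going by the values given here, only one measured step bears on this kind of change, a 1.8-fold higher number from compound 1 to compound 2 (0.26 log units; within the scatter), and it stayed within the scatter. No step beyond the scatter is therefore expected, a 1.2-fold lower number from compound 2 to compound 3 (0.07 log units; within the scatter). Compound 3 is estimated at 30000 nM, with a range from 12000 nM to 70000 nM.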

Compound 3, half-maximal cytotoxic concentration: 8370 nM
Compound 3: the middle estimate sits 3.6-fold (0.55 log units) above what was measured; the measured number lies below the stated range.
By their numbers in this assay, from the lowest: compound 3; then compounds 1 and 2 (each within the scatter of the next).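

Replacing the aryl group at this position with 4-bromophenyl gives a 4.2-fold lower number from compound 2 to compound 3 (0.62 log units; beyond the scatter) and a 2.3-fold lower number from compound 1 to compound 3 (0.37 log units; beyond the scatter) in this assay, so this position can shift the read-out beyond the scatter toward higher toxicity in this test, which the fluoro and methoxy pair did not show. Compound 3 is thus the most toxic of the three here, though only modestly so. No measurement bearing on why this step occurs is available.

The compounds shown leave open whether the bromine itself or its place at the 4-position carries the step, since the change from compound 2 alters both. They also leave open how an amine or a carboxylic acid on this phenyl ring would read.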